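The compounds below may be only part of what the source reports. "The series", "measured", "known", "first", "only" and "open" are said of these compounds alone.

Two compounds built on a shared core have so far been assessed in an ADME assay on microsomes from liver (Homo sapiens) for metabolic stability, read by LC-MS, with NADPH named in the record, with a stated time of 60 min, tested at 1 uM, in the absence of a further agent; on this read-out higher numbers stand for a more stable compound and lower numbers for a less stable compound. Compound 1, `COc1cc(-c2c(C)nc3c(N4CC[C@@H](NC(C)=O)C4)cc(C)nn23)cc(OC)c1OC`, is one of them. In this assay compound 1 returns a limit of the assay rather than a number, > 95%. Compound 2, `COc1ccc(-c2c(C)nc3c(N4CC[C@@H](NC(=O)NC(C)C)C4)cc(C)nn23)cc1OC`, is the other. In this assay compound 2 likewise returns a limit of the assay, > 95%. Among the compounds with values here, compound 2 thus stands where every value so far stands, at the limit of > 95% in this assay, at which 2 of the 2 values shown sit, so no number yet sets either compound apart from the other.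

Compound 3, `COc1ccc(-c2c(C)nc3c(N4CC[C@@H](NS(=O)(=O)c5ccc(Cl)cc5)C4)cc(C)nn23)cc1OC`, has not yet been measured in this assay. It differs from compound 2 in one place, ((4-chlorophenyl)sulfonyl in place of isopropylcarbamoyl on an amine nitrogen). Within the data shown here, no measured pair of compounds shows a change of this kind, so the size of the step is not yet known from the numbers. The expectation here is a moderate fall, a number at least 17 percentage points lower from compound 2 to compound 3 (beyond the scatter), reaching beyond the usual scatter but not by a large margin. On that basis compound 3 is estimated to give 78% in this assay, with a range from 55% to 95%.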

Compound 3, percent of the compound remaining: > 95%
Compound 3 gave a limit, no number (the forecaster's own chance of this, stated with the estimate: 35%); at least 17 percentage points between middle value and limit.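

In this assay compound 3 returns a limit of the assay, > 95%, and compound 2 also rests at a limit, so no step can be read between them. All the compounds shown stand at one place: the limit of > 95% in this assay, at which 3 of the 3 values shown sit.

From the compounds shown here alone, what remains open is which change to the shared core or its side groups, if any, would bring the percent remaining to a measurable number.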